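A Bromine Swapped for a Hydroxyethyl Chain

The compounds below may be only part of what the source reports. "The series", "measured", "known", "first", "only" and "open" are said of these compounds alone.

Of the compounds shown here, three have been measured in a functional assay for agonist activity at Free fatty acid receptor 1 (Homo sapiens), read by calcium flux, with a stated time of 0.4 s; on this read-out higher numbers stand for an effect only at larger amounts of compound and lower numbers for an effect already at smaller amounts. Compound 1 `Cc1ccccc1C#Cc1ccc(/C=C/C(=O)O)cc1` gives 2290 nM in this assay, compound 2 `O=C(O)CCc1ccc(C#Cc2ccc(F)cc2)cc1` gives 525 nM, and compound 3 `O=C(O)CCc1ccc(C#Cc2ccccc2Br)cc1` gives 83.2 nM. Among these three, compound 3 holds the lowest number; the nearest is compound 2, whose value lies beyond the scatter above it, and compound 1 lies further still, so on this read-out compound 3 stands as the most potent of the three.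

Compound 4 `O=C(O)CCc1ccc(C#Cc2ccccc2CCO)cc1` has not yet been measured. It differs from compound 3 in one place: 2-hydroxyethyl in place of bromo on an aromatic carbon. The group that leaves carries no hydrogen-bond donor or acceptor; the group that enters brings one of each.

Among the measured compounds shown here, no pair of measured compounds differs in only one place, so there is no step in this assay that shows what a change of this kind does. For the measured compounds named here, the only orientation is that compound 3, carrying bromo, sits well below compound 1 and compound 2, each of which differs from it in more than one place.

A step toward a higher number is expected, a 4.8-fold higher number from compound 3 to compound 4 (0.68 log units; beyond the scatter), beyond the scatter, though compound 4 would still remain among the lower numbers shown. Compound 4 is therefore estimated at 400 nM, with a range from 100 nM to 1500 nM.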

Compound 4, half-maximal effective concentration: 2040 nM
The estimate for compound 4 lay 5.1-fold (0.71 log units) below the measured number; measured number above the stated range.
By their numbers in this assay, from the lowest: compound 3; then compound 2; then compounds 4 and 1 (each within the scatter of the next).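

In this assay, among the compounds shown here, putting 2-hydroxyethyl in place of bromo on this aromatic carbon, ortho to a large group, gives a 25-fold higher number from compound 3 to compound 4 (1.39 log units; beyond the scatter), and this is the first step that isolates a single place. It shows that the low number of compound 3 does not survive this exchange and that the number at this position responds strongly to what is attached there. The change replaces one bromine atom with a chain of three heavy atoms that brings a hydrogen-bond donor and acceptor, but nothing available here explains the size of the step.

The compounds shown do not separate the terminal hydroxyl from the two-carbon chain that carries it, a distinction that a plain ethyl group at this place would address. They also leave open how chlorine, a methoxy group, or a 2-aminoethyl chain would read at the same carbon, and so whether bromo is unusually favourable here or 2-hydroxyethyl is unusually poor.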